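The source may report more compounds than this note shows. Statements on the series, on what has been measured and on what is new or still open speak of the compounds shown alone.

Three compounds sharing one core have been measured in an assay on striatum for inhibition of sodium-dependent dopamine transporter (Rattus norvegicus); a lower number here means a stronger inhibitor, a higher number a weaker inhibitor:

compound 1 `c1ccc(C(c2ccccc2)[C@@H]2CC[C@H](NCc3ccc[nH]3)CO2)cc1`: 43.2 nM
compound 2 `c1ccc(C(c2ccccc2)[C@@H]2CC[C@H](NCc3ccccn3)CO2)cc1`: 209 nM
compound 3 `c1ccc(C(c2ccccc2)[C@@H]2CC[C@H](NCc3cccnc3)CO2)cc1`: 145 nM

Compound 3 stands second highest of the three numbers. Its nearest neighbour is compound 2, with a 1.4-fold lower number from compound 2 to compound 3 (0.16 log units; within the scatter), a difference too small to count. Compound 1 lies furthest away, with a 3.4-fold higher number from compound 1 to compound 3 (0.53 log units; beyond the scatter), so compound 1 is the only one of the three whose number is clearly lower.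

The next compound is compound 4 `c1ccc(C(c2ccccc2)[C@@H]2CC[C@H](NCc3ccncc3)CO2)cc1`. It differs from compound 3 in one place: pyridin-4-yl in place of pyridin-3-yl on a saturated chain carbon bound to an amine nitrogen.

Among the compounds with values here, two measured steps bear on this kind of change. Swapping 1H-pyrrol-2-yl for pyridin-2-yl gave a 4.8-fold higher number from compound 1 to compound 2 (0.68 log units; beyond the scatter), and swapping it for pyridin-3-yl gave a 3.4-fold higher number from compound 1 to compound 3 (0.53 log units; beyond the scatter). Between the two pyridines themselves the step was a 1.4-fold lower number from compound 2 to compound 3 (0.16 log units; within the scatter), within the scatter. Moving the ring nitrogen from one pyridine to another therefore did not shift the number beyond the scatter, and the step to compound 4 is expected to behave the same way, with no clear movement in either direction.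

Compound 4 is therefore estimated at 170 nM, with a range from 70 nM to 420 nM, which means an expected step of a 1.2-fold higher number from compound 3 to compound 4 (0.07 log units; within the scatter).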

Compound 4, inhibition constant: 28.3 nM
The estimate for compound 4 lay 6.0-fold (0.78 log units) above the measured number; the whole stated range lies above it.
By their numbers in this assay, from the lowest: compounds 4 and 1 (each within the scatter of the next); then compounds 3 and 2 (each within the scatter of the next).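

In this assay, the place of the nitrogen in the pyridine ring clearly matters on this saturated chain carbon: pyridin-4-yl in place of pyridin-3-yl gives (a 5.1-fold lower number from compound 3 to compound 4 (0.71 log units; beyond the scatter)), and pyridin-4-yl in place of pyridin-2-yl gives (a 7.4-fold lower number from compound 2 to compound 4 (0.87 log units; beyond the scatter)). The earlier step among the pyridines therefore did not hold for all of them, even though the groups exchanged here have the same atoms, joined differently. Pyridin-4-yl in place of 1H-pyrrol-2-yl gives (a 1.5-fold lower number from compound 1 to compound 4 (0.18 log units; within the scatter)), a step within the scatter, so the clearly higher numbers seen earlier belong to pyridin-2-yl and pyridin-3-yl and not to every pyridine.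

On these data alone, it remains open whether pyrimidin-4-yl, a pyridin-4-yl ring carrying a methyl group, or a longer chain bearing the pyridin-4-yl would keep the number of compound 4 (28.3 nM) in this assay. Nothing measured here bears on why the place of the ring nitrogen matters.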